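Triazene Antiproliferatives: From Dimethylamino to Ethyl(methyl)amino

This account rests on a few compounds, and the source may have more. Where it says the series, first, only, none or still open, it means among the compounds named here.

Measured compounds:
compound 1, `CN(C)/N=N/c1ccc(C(N)=O)cc1`, 3.51
compound 2, `COC(=O)c1ccc(/N=N/N(C)C)cc1`, 3.2
compound 3, `CN(C)/N=N/c1ccc(C(N)=O)cc1C(N)=O`, 3.27

In a functional assay on L1210 cells (Mus musculus) for antiproliferative activity (on this read-out higher numbers stand for higher potency (the scale is a negative logarithm) and lower numbers for lower potency), compound 1 stands highest of the three numbers. Its nearest neighbour is compound 3, reached by carbamoyl in place of hydrogen on an aromatic carbon, a step of a number 0.24 log units lower from compound 1 to compound 3 (within the scatter), so the two cannot be ordered. Compound 2, with methoxy in place of amino on a carbonyl carbon, sits further off, a number 0.31 log units lower from compound 1 to compound 2 (beyond the scatter), a modest loss that does clear the scatter.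

The next compound, compound 4, `CCN(C)/N=N/c1ccc(C(N)=O)cc1`, differs from compound 1 in a different part of the molecule: methyl in place of hydrogen on a saturated chain carbon bound to an amine nitrogen, so that the dimethylamino group becomes ethyl(methyl)amino. Neither measured step bears on this change; both alter the carbonyl-bearing end of the molecule and leave the amine nitrogen and its substituents untouched. There is thus no measured guide for the size or direction of this step, and the smallest plausible expectation is a change that stays within the scatter around compound 1. The step from compound 1 to compound 4 is therefore estimated at a number 0.01 log units lower from compound 1 to compound 4 (within the scatter), with a wide allowance. Compound 4 is expected to give 3.5, between 3.05 and 3.95.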

Compound 4, logarithm of the reciprocal of the active concentration, log(1/C): 3.66
Compound 4: middle estimate off by 0.16 log units, on the low side; the range from low to high includes it.
By their numbers in this assay, from the lowest: compounds 2, 3, 1 and 4 (each within the scatter of the next, the first and the last beyond it).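

The change from dimethylamino to ethyl(methyl)amino gives, in this assay, a number 0.15 log units higher from compound 1 to compound 4 (within the scatter), so the two compounds cannot be ordered and the added methyl has no effect that can be read on this scale. Among the compounds shown here, this is the first reading at the amine nitrogen, as the two earlier steps changed the molecule elsewhere, and it shows that one more carbon on a saturated chain carbon bound to that nitrogen costs nothing that clears the scatter, unlike the methoxy change, which gives a number 0.31 log units lower from compound 1 to compound 2 (beyond the scatter). Nothing available here explains why this position responds as it does.

As far as these compounds go, what remains open is how far this tolerance extends on the amine nitrogen: one ethyl group says nothing about diethylamino, or about a longer chain such as propyl or butyl in its place. From the compounds shown here alone, it is also open whether ethyl(methyl)amino would behave the same way on the core of compound 2 or of compound 3, where the methyl ester or the second carbamoyl is present.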